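From Methyl to Trifluoromethyl: An Antiproliferative Estimate

The source may hold more compounds than are shown below. What is called first, only, known or untested is meant among the compounds shown, and "the series" means these compounds.

Two compounds with a shared core, compound 1 `CNc1nc(-c2cc(OC)c(OC)c(OC)c2)c(-c2ccc3ccccc3c2)s1` and compound 2 `CNc1nc(-c2cc(OC)c(OC)c(OC)c2)c(-c2ccc(C)cc2)s1`, have been measured in a functional assay on A549 cells (Homo sapiens) for antiproliferative activity, read by MTT assay, with a stated time of 72 h; a higher number here means a weaker inhibitor, a lower number a stronger inhibitor. There, compound 2 gives 125 nM and compound 1 gives 151 nM. These two numbers lie within the usual scatter of repeated measurements, so compound 2 stands level with compound 1.

Compound 3 `CNc1nc(-c2cc(OC)c(OC)c(OC)c2)c(-c2ccc(C(F)(F)F)cc2)s1` comes from compound 2 through a single change: trifluoromethyl in place of methyl on an aromatic carbon. In words, trifluoromethyl takes the place of methyl on an aromatic carbon, para to a large group. Within the data shown here, no measured pair shows this swap, so the data offer no direct guide and any forecast stays loose. A moderate move towards a higher number in this assay is expected, meaning somewhat weaker inhibition. The estimated step is a 2.6-fold higher number from compound 2 to compound 3 (0.41 log units; beyond the scatter). For compound 3 the estimated value is 320 nM, with an expected range from 90 nM to 1300 nM.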

Compound 3, half-maximal inhibitory concentration: 4570 nM
Beside the measured number, compound 3's estimate is 14-fold (1.15 log units) below it; the whole stated range lies below it.
By their numbers in this assay, from the lowest: compounds 2 and 1 (each within the scatter of the next); then compound 3.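

In this assay, putting trifluoromethyl in place of methyl gives a 37-fold higher number from compound 2 to compound 3 (1.56 log units; beyond the scatter) and so produces a large step, well beyond the scatter. This shows that the aromatic carbon para to a large group is sensitive to what sits there: one swap at this place markedly weakens inhibition, even though neither group carries a hydrogen-bond donor, a hydrogen-bond acceptor or a net charge. No available measurement explains a step of this size.

Going by these compounds, it remains open whether a chlorine atom, an ethyl group or an amine at this same place would stay close to compound 2 or fall towards compound 3. A single pair also leaves open whether this swap would have a similar effect at another place on the shared core.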